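Rearranging the side chain of compound 2

The compounds below may be only part of what the source reports. "The series", "measured", "known", "first", "only" and "open" are said of these compounds alone.

For the measured compounds named here, in a functional assay on the whole organism with Mus musculus as the target (a lower number here means that less compound is needed, a higher number that more compound is needed for the effect), compound 2 `CNC(=O)[C@@H](C)NCc1ccc(OCc2ccccc2)cc1` gives 40.5 mg/kg, the lowest number of the three measured so far. Compound 3 `CNC(=O)[C@@H](CC(C)C)NCc1ccc(OCc2ccccc2)cc1` gives 192 mg/kg, and compound 1 `NC(=O)CNCc1ccccc1` gives 490 mg/kg. Compound 4 `CC[C@H](NCc1ccc(OCc2ccccc2)cc1)C(N)=O` has not yet been measured. It has the same atoms as compound 2, joined differently: 1-carbamoylpropyl in place of 1-(methylcarbamoyl)ethyl on an amine nitrogen.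

Going by the values given here, only one measured step bears on this change: a 4.7-fold higher number from compound 2 to compound 3 (0.68 log units; beyond the scatter). That step puts isopropyl in place of hydrogen on a saturated chain carbon and lies beyond the scatter. It is only a loose guide, since it adds atoms, whereas compound 4 rearranges the ones compound 2 already has. Among the compounds with values here, no measured step shows the exchange of 1-(methylcarbamoyl)ethyl for 1-carbamoylpropyl directly, so the direction remains open and a wide range is warranted. The expected size is no more than the scatter, and the estimated step is a 1.1-fold higher number from compound 2 to compound 4 (0.05 log units; within the scatter). For compound 4, the estimated value is 45 mg/kg, with an expected range from 15 mg/kg to 130 mg/kg.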

Compound 4, dose for half-maximal effect: 119 mg/kg
Compound 4: middle estimate off by 2.6-fold (0.42 log units), on the low side, within the range that was stated.
By their numbers in this assay, from the lowest: compound 2; then compounds 4 and 3 (each within the scatter of the next); then compound 1.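

In this assay, 1-carbamoylpropyl in place of 1-(methylcarbamoyl)ethyl on an amine nitrogen gives a 2.9-fold higher number from compound 2 to compound 4 (0.47 log units; beyond the scatter). The earlier step, a 4.7-fold higher number from compound 2 to compound 3 (0.68 log units; beyond the scatter), added atoms, whereas the two groups exchanged here have the same counts of heavy atoms, hydrogen-bond donors and acceptors, so at this position the number responds to how the atoms are joined, not only to how many there are. No measurement shown here explains the shift.

The exchange makes two edits at once, and the compounds shown cannot separate them. A 1-carbamoylethyl group or a 1-(methylcarbamoyl)propyl group on the same amine nitrogen would show each edit alone, and a carboxylic acid in place of the amide remains a further open variation.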